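A few compounds are considered here, and "the series" means these few. Any claim that something is new, unique, unknown or untested is made for them only; others in the source may bear on it.

Working notes on the series. Compound 1 `COC(=O)c1sc2cc(C#Cc3ccc(OC)cc3)cnc2c1N`, compound 2 `COC(=O)c1sc2cc(C#Cc3cccc(N)c3)cnc2c1N` and compound 3 `COC(=O)c1sc2cc(C#Cc3ccccc3F)cnc2c1N` share one core and differ only in the aryl group on the triple-bonded carbon. In a functional assay on MCF7 cells (Homo sapiens) for inhibition, read by sulforhodamine B assay, with a stated time of 48 h (on this read-out higher numbers stand for weaker inhibition of growth and lower numbers for stronger inhibition of growth), compound 1 gives 460 nM. In this assay compound 2 gives 10800 nM. For compound 3 this assay reports only a limit, > 150000 nM, and no number. Compound 3 thus stands at the weak end of the three values shown, at the limit of > 150000 nM in this assay, at which 1 of the 3 values shown sits. Every measured step across the aryl group is large: a 23-fold higher number from compound 1 to compound 2 (1.37 log units; beyond the scatter); an at least 320-fold higher number from compound 1 to compound 3 (2.51 log units; beyond the scatter); an at least 13-fold higher number from compound 2 to compound 3 (1.14 log units; beyond the scatter). Compound 4 `COC(=O)c1sc2cc(C#Cc3ccsc3)cnc2c1N` is not yet measured; it arises from compound 3 by thiophen-3-yl in place of 2-fluorophenyl on a triple-bonded carbon. All three measured steps exchange the aryl group on the same triple-bonded carbon and so bear on this change, and each of them moved this assay by a large amount. A large step is therefore expected here too, toward a lower number, with compound 3 at the limit and the other two aryl groups both well inside the measured range. Compound 4 is expected to give about 20000 nM in this assay, within a range from 3000 nM to 150000 nM. That estimate means an expected step of an at least 7.5-fold lower number from compound 3 to compound 4 (0.87 log units; beyond the scatter).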

Compound 4, concentration for 50% growth inhibition: 27700 nM
Compound 4: the middle estimate sits 1.4-fold (0.14 log units) below what was measured, and the stated range covers the measured number.
By their numbers in this assay, from the lowest: compound 1; then compound 2; then compound 4. At a limit, above all of these: compound 3.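

Thiophen-3-yl is the first group on this triple-bonded carbon that is not a six-membered aromatic ring of carbon only, and in this assay its exchange for 2-fluorophenyl gives an at least 5.4-fold lower number from compound 3 to compound 4 (0.73 log units; beyond the scatter). Going by these compounds alone, its exchange for 3-aminophenyl gives the first modest step at this carbon, a 2.6-fold higher number from compound 2 to compound 4 (0.41 log units; beyond the scatter), so not every aryl exchange here is large, while its exchange for 4-methoxyphenyl remains large, with a 60-fold higher number from compound 1 to compound 4 (1.78 log units; beyond the scatter). Compound 3 remains a limit and not a number in this assay: the limit of > 150000 nM in this assay, at which 1 of the 4 values shown sits.

The single thiophen-3-yl ring does not separate the change in ring size from the entry of the sulfur atom, and furan-3-yl or pyridin-3-yl on the same carbon would bear on that question. Also open, as far as these compounds go, is whether the low number of compound 1 belongs to the methoxy group itself, which an ethoxy or hydroxy group in its place on the phenyl ring would test, and whether a saturated ring such as cyclohexyl or an alkyl chain on the triple-bonded carbon would keep any growth inhibition.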